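Working notes: 2-fluorophenyl to 4-fluorophenyl

The compounds below may be only part of what the source reports. "The series", "measured", "known", "first", "only" and "open" are said of these compounds alone.

Among the measured compounds shown here, in a functional assay on A549 cells (Homo sapiens) for antiproliferative activity, read by MTT assay, with a stated time of 24 h (on this read-out higher numbers stand for weaker inhibition and lower numbers for stronger inhibition), only two compounds have been measured. Compound 1 `Cc1cccc(NNC(=O)c2ccccc2NS(=O)(=O)c2cnc(O)nc2O)c1`, with 3-methylphenyl on an amine nitrogen, gives > 20000 nM, which is a limit and not a number. For the measured compounds named here, compound 2 `O=C(NNc1ccccc1F)c1ccccc1NS(=O)(=O)c1cnc(O)nc1O`, with 2-fluorophenyl at that place, gives 9610 nM, the only actual number so far.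

Next is compound 3 `O=C(NNc1ccc(F)cc1)c1ccccc1NS(=O)(=O)c1cnc(O)nc1O`, with 4-fluorophenyl in place of 2-fluorophenyl on an amine nitrogen. The two have the same atoms, joined differently.

Going by the values given here, the one measured step, an at least 2.0-fold lower number from compound 1 to compound 2 (0.31 log units; beyond the scatter), bears on this change only loosely, since it exchanges a different group and one end of it is a limit. Among the compounds with values here, no measurement yet covers a move of the fluorine around the ring. No step beyond the scatter is therefore expected in this assay, in either direction. The estimated step is a 1.2-fold higher number from compound 2 to compound 3 (0.10 log units; within the scatter), which is expected to stay within the scatter. The upper end of the range is held at the limit of > 20000 nM in this assay, at which 1 of the 2 values shown sits. For compound 3 the estimated value is 12000 nM, with an expected range of 5000 nM to 20000 nM.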

Compound 3, half-maximal inhibitory concentration: > 20000 nM
Compound 3 was reported as a limit (the forecaster's own chance of this, stated with the estimate: 30%); middle value at least 1.6-fold (0.22 log units) from the limit.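

In this assay, this position on the amine nitrogen responds to where the fluorine sits on the phenyl ring, not only to which group is present: with the same atoms joined differently, 4-fluorophenyl in place of 2-fluorophenyl gives an at least 2.0-fold higher number from compound 2 to compound 3 (0.31 log units; beyond the scatter). Compound 3 gives > 20000 nM, which is a limit of the assay and not a number. Compound 2, with 2-fluorophenyl, is still the only compound with a number, and the step between compound 1 and compound 3 cannot be read: the limit of > 20000 nM in this assay, at which 2 of the 3 values shown sit.

On these data alone, it remains open how 3-fluorophenyl would read at this place, and whether the number of compound 2 depends on fluorine itself or would also hold with 2-chlorophenyl or 2-methylphenyl on the same amine nitrogen. Also open, as far as these compounds go, is whether a phenyl ring carrying an amine or a carboxylic acid at this place, or a pyridyl ring in its stead, would bring the number below that of compound 2, 9610 nM.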